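The compounds below may be only part of what the source reports. "The series", "measured", "known", "first", "only" and "open" are said of these compounds alone.

Compound 1 `Cc1cc(S(=O)(=O)/N=C(\N)n2nccc2-c2ccccc2)c(SCc2ccccc2Cl)cc1Cl`: in an ADME assay on microsomes from liver (Homo sapiens) for metabolic stability, read by LC-MS, using NADPH, tested at 5 uM (a higher number here means that the compound lasts longer, a lower number that the compound disappears faster), compound 1 gives 0.226 h.
Compound 2 `Cc1cc(-c2ccccc2)n(/C(N)=N/S(=O)(=O)c2cc(C)c(Cl)cc2SCc2ccccc2C(F)(F)F)n1`: in this assay compound 2 gives 0.306 h.
Compound 3 `Cc1cc(-c2ccccc2)n(/C(N)=N/S(=O)(=O)c2cc(C)c(Cl)cc2SCc2cccc3ccccc23)n1`: in this assay compound 3 gives 0.256 h.

The three measured compounds share one core and differ only in the aryl group on the saturated chain carbon bound to sulfur. Compound 1 holds the lowest of the three numbers, yet its gaps to compound 3 and to compound 2 both lie within the scatter, so no ordering among them can be claimed. Among the measured compounds shown here, the one step that can be read, a 1.2-fold lower number from compound 2 to compound 3 (0.08 log units; within the scatter), is also within the scatter, and it swaps the whole aryl group rather than a single substituent.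

Compound 4 `Cc1cc(S(=O)(=O)/N=C(\N)n2nccc2-c2ccccc2)c(SCc2ccccc2C)cc1Cl` is the unmeasured partner of compound 1. The change is methyl in place of chloro on an aromatic carbon, a move from 2-chlorobenzyl to 2-methylbenzyl. For the measured compounds named here, no measured pair shows this exchange of chloro for methyl, so the only guidance is that the aryl swap from compound 2 to compound 3 left the number essentially unchanged. Compound 4 is therefore expected to sit close to compound 1, with the step of a 1.1-fold lower number from compound 1 to compound 4 (0.05 log units; within the scatter) expected to stay within the scatter. The estimate for compound 4 in this assay is 0.2 h, with a range from 0.1 h to 0.4 h.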

Compound 4, half-life: 0.0802 h
For compound 4 the middle estimate is 2.5-fold (0.40 log units) above the measured one; the measured number lies below the stated range.
By their numbers in this assay, from the lowest: compound 4; then compounds 1, 3 and 2 (each within the scatter of the next).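

In this assay, methyl in place of chloro on the aromatic carbon ortho to a large group gives a 2.8-fold lower number from compound 1 to compound 4 (0.45 log units; beyond the scatter), a modest step but the first in this set that stands beyond the scatter. The earlier step, which replaced a whole aryl group on the chain carbon bound to sulfur, stayed within the scatter, so this position had not yet shown any measurable response in half-life. Compound 4 now shows that changing one heavy atom on the benzyl ring, from chlorine to carbon, is enough to produce a readable change, although nothing available bears on why the number moves in this direction.

Among the compounds shown here, with only one pair at this place, it remains open how other groups there would read, such as a fluoro, a methoxy or a nitrile, and whether 2-chlorobenzyl stands out or 2-methylbenzyl does. Going by these compounds, it is also open whether the exchange of chloro for methyl would give a step of similar size on the core of compound 2.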